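Swapping tert-butyl for cyano on an aromatic ring

The compounds below may be only part of what the source reports. "The series", "measured", "known", "first", "only" and "open" are said of these compounds alone.

In an ADME assay on L02 cells (Homo sapiens) for cytotoxicity, read by MTT assay, with a stated time of 24 h (on this read-out higher numbers stand for weaker inhibition and lower numbers for stronger inhibition), compound 1 (`COc1cc(/C=C2\CN(C)C/C(=C\c3ccccc3F)C2=O)cc(OC)c1`) gives 11900 nM and compound 2 (`COc1cc(/C=C2\CN(C)C/C(=C\c3ccccc3F)C2=O)cc(OC)c1OC`) gives 12100 nM on a shared core. Compound 3 (`CN1C/C(=C\c2ccc(C(C)(C)C)cc2)C(=O)/C(=C/c2ccccc2F)C1`) stands highest of the three at 25800 nM and so inhibits most weakly. Compound 4 (`CN1C/C(=C\c2ccc(C#N)cc2)C(=O)/C(=C/c2ccccc2F)C1`) carries cyano in place of tert-butyl on an aromatic carbon. Among the measured compounds shown here, the sole measured step (a 1.0-fold higher number from compound 1 to compound 2 (0.01 log units; within the scatter)) is a different change, methoxy in place of hydrogen, so it is only a weak guide. For the measured compounds named here, a fall toward compound 2 at 12100 nM is expected, though no measured compound carries cyano. The estimated change is modest (a 1.7-fold lower number from compound 3 to compound 4 (0.24 log units; within the scatter)) with wide uncertainty. For compound 4 the estimated value is 15000 nM with an expected range from 7000 nM to 30000 nM in this assay once measured.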

Compound 4, half-maximal inhibitory concentration: 11000 nM
For compound 4 the middle estimate is 1.4-fold (0.13 log units) above the measured one, within the range that was stated.
By their numbers in this assay, from the lowest: compounds 4, 1 and 2 (each within the scatter of the next); then compound 3.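

At this position on the aromatic ring, this assay does respond to the group carried there: cyano in place of tert-butyl gives a change beyond the scatter (a 2.3-fold lower number from compound 3 to compound 4 (0.37 log units; beyond the scatter)). The earlier step, methoxy in place of hydrogen (a 1.0-fold higher number from compound 1 to compound 2 (0.01 log units; within the scatter)), stayed within the scatter. Cyano differs from tert-butyl both in heavy atoms and in its hydrogen-bond acceptor, and no available evidence separates these differences or explains the shift.

On these data alone, whether an amine or a carboxylic acid at this position would lower the number further remains open.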